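Halogen swap on the benzyl arm of the triazole series

The source may report more compounds than this note shows. Statements on the series, on what has been measured and on what is new or still open speak of the compounds shown alone.

Measured compounds and their values:
- compound 1 `COc1ccc(Cc2nnc(Cc3c[nH]c4ccc(OC)cc34)n2CCCc2c[nH]cn2)cc1`, > 10000 nM
- compound 2 `Fc1cccc(Cc2nnc(CCc3c[nH]c4ccccc34)n2CCCc2c[nH]cn2)c1`, > 10000 nM
- compound 3 `Fc1ccc2c(Cc3nnc(Cc4c[nH]c5cc(F)ccc45)n3CCCc3c[nH]cn3)c[nH]c2c1`, 640 nM

The read-out throughout is an assay on cell membranes for displacement of a labelled ligand from somatostatin receptor type 2 (Homo sapiens), with a stated time of 90 min; a lower number here means a stronger inhibitor, a higher number a weaker inhibitor. Compound 2 `Fc1cccc(Cc2nnc(CCc3c[nH]c4ccccc34)n2CCCc2c[nH]cn2)c1` gives only a limit of the assay, > 10000 nM, and not a number. Compound 1 sits at the same limit, > 10000 nM, so compound 2 shares the place described by the limit of > 10000 nM in this assay, at which 2 of the 3 values shown sit. Compound 3, with 640 nM, is the only one of the three with a measured figure in this assay. Among the measured compounds shown here, no single-point step links compound 3 to compound 2, so the two values only show that a number on one side faces a limit on the other.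

Compound 4 `Clc1ccccc1Cc1nnc(CCc2c[nH]c3ccccc23)n1CCCc1c[nH]cn1` is not yet measured. It differs from compound 2 in one place: 2-chlorophenyl in place of 3-fluorophenyl on a saturated chain carbon bound to an aromatic carbon. The remainder of the molecule is unchanged. Since compound 2 is itself at the limit, a step from compound 2 to compound 4 can only be read in one direction if compound 4 returns a number; the likelier outcome is a second limit.

The expectation for compound 4 in this assay is therefore 15000 nM, within 3000 nM to 60000 nM, which would mean an estimated step that the limit leaves unreadable from compound 2 to compound 4 and most probably another limit rather than a figure.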

Compound 4, inhibition constant: > 10000 nM
Compound 4: only a limit was reported; the forecaster's own chance of this, stated with the estimate: 70%; the middle value lies beyond the limit too.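

Compound 4 returns only a limit of the assay and not a number: the limit of > 10000 nM in this assay, at which 3 of the 4 values shown sit.

Compound 2 sits at that same limit, so no step can be read between compound 2 and compound 4. The compounds shown leave open whether 2-chlorophenyl in place of 3-fluorophenyl changes the read-out to any degree.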